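The compounds below may be only part of what the source reports. "The series", "measured", "known", "first", "only" and "open" are said of these compounds alone.

Compounds measured so far:

Compound 1, `COc1cc(OC)c(OC)cc1/C=C/C(=O)c1ccc(C)cc1`, gives 42200 nM in a functional assay on HeLa cells (Homo sapiens) for inhibition, read by MTT assay, with a stated time of 72 h; a lower number here means a stronger inhibitor, a higher number a weaker inhibitor.
Compound 2, `COc1cc(OC)c(OC)cc1/C=C/C(=O)c1cc(OC(C)=O)ccc1OC(C)=O`, gives 57900 nM in this assay.
Compound 3, `COc1cc(OC)c(OC)cc1/C=C/C(=O)c1cc(Cc2ccccc2)cc(Cc2ccccc2)c1`, gives 26900 nM in this assay.

All three of these compounds share the same core and differ only in the ring attached to the carbonyl carbon. Their values in this assay lie close together. Compound 1 stands second highest of the three, and both its neighbours sit within the usual scatter of it: compound 2 with 57900 nM and compound 3 with 26900 nM. No ordering among the three can be claimed from these numbers.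

Compound 4, `COc1cc(OC)c(OC)cc1/C=C/C(=O)c1ccc(O)cc1O`, has not yet been measured in this assay. It differs from compound 1 in one place: 2,4-dihydroxyphenyl in place of 4-methylphenyl on a carbonyl carbon. Within the data shown here, since no step between measured compounds is available here, there is no direct guide for how this change will read out. Given how tightly the three measured values cluster, the expected step is none beyond the scatter, with perhaps a slight lean toward a lower number; the estimated step is a 1.4-fold lower number from compound 1 to compound 4 (0.15 log units; within the scatter). Compound 4 is therefore expected to give about 30000 nM in this assay, with a likely range from 8000 nM to 120000 nM.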

Compound 4, half-maximal inhibitory concentration: 37600 nM
Estimate against measurement, compound 4: 1.3-fold (0.10 log units) below, within the range that was stated.
By their numbers in this assay, from the lowest: compounds 3, 4, 1 and 2 (each within the scatter of the next, the first and the last beyond it).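

Among these compounds, compound 4 gives the first readable step at this position, the ring on the carbonyl carbon: in this assay, 2,4-dihydroxyphenyl in place of 4-methylphenyl gives a 1.1-fold lower number from compound 1 to compound 4 (0.05 log units; within the scatter). Among the compounds shown here, the three earlier compounds formed no such step, so they could not show that this exchange, which replaces a ring with no hydrogen-bond donors or acceptors by one with two of each, leaves the two values within the scatter of each other. No measurement shown here bears on why the exchange has so little effect on this result.

The compounds shown leave open whether a ring on the carbonyl carbon bearing an amine or a carboxylic acid would give a step beyond the scatter, and whether a single hydroxy group would read differently from the pair in 2,4-dihydroxyphenyl. They also leave open whether replacing the methoxy groups of the shared core with hydroxy groups or longer ethoxy groups would matter more in this assay than the changes seen so far on the ring at the carbonyl carbon.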